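This account rests on a few compounds, and the source may have more. Where it says the series, first, only, none or still open, it means among the compounds named here.

Compounds measured in an ADME assay on the whole organism (Macaca fascicularis) for pharmacokinetics, read by LC-MS, using cassette dosing, at a dose of 1 mg/kg by the oral route; a higher number here means more compound in the circulation at the dose given, a lower number less compound in the circulation:
- compound 1, `C[C@H](c1ccc(-c2cc(Cl)ccc2-c2nc(=O)o[nH]2)cc1)N(CC1CC1)c1nc2c(C(=O)O)cccc2o1`, 976 nM
- compound 2, `CCCCN(c1nc2c(C(=O)O)cccc2o1)[C@H](C)c1ccc(-c2ccccc2-c2nnn[nH]2)cc1`, 238 nM
- compound 3, `C[C@H](c1ccc(-c2ccccc2-c2nc(=O)o[nH]2)cc1)N(CC1CC1)c1nc2c(C(=O)O)cccc2o1`, 7710 nM

Of these three, compound 2 gives the lowest maximal plasma concentration in this assay, 238 nM, while compound 1 stands nearest to it with 976 nM and compound 3 furthest with 7710 nM. Within the data shown here, the one measured step among them, a 7.9-fold higher number from compound 1 to compound 3 (0.90 log units; beyond the scatter), concerns the chloro group on the other aromatic ring and not the carboxy group of the shared core.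

Compound 4, `CCCCN(c1nc2c(NC(C)=O)cccc2o1)[C@H](C)c1ccc(-c2ccccc2-c2nnn[nH]2)cc1`, differs from compound 2 in one place: acetamido in place of carboxy on an aromatic carbon. Among the measured compounds shown here, no measured step bears on this change; the only step recorded, from compound 1 to compound 3, touches a different part of the molecule. The expectation for compound 4 in this assay therefore rests on compound 2 alone, with a wide range, and the step of a 1.3-fold higher number from compound 2 to compound 4 (0.10 log units; within the scatter) is estimated without a firm direction. Compound 4 is expected to give about 300 nM in this assay, with a range from 60 nM to 1500 nM.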

Compound 4, maximal plasma concentration: 26.6 nM
The estimate for compound 4 lay 11-fold (1.05 log units) above the measured number; the measured number lies below the stated range.
By their numbers in this assay, from the lowest: compound 4; then compound 2; then compound 1; then compound 3.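

In this assay, acetamido in place of carboxy on this aromatic carbon gives an 8.9-fold lower number from compound 2 to compound 4 (0.95 log units; beyond the scatter), the first measured change at this position among these compounds. The position is therefore not indifferent to its substituent: the step lies beyond the scatter, although the two groups have the same hydrogen-bond donor and acceptor counts, and neither adds a ring or a net charge. Nothing measured here accounts for the drop.

Going by these compounds, it remains open whether the same replacement would lower the number to a similar extent in compound 3, whose other parts differ from those of compound 2. Also open, on these data alone, is where a primary amide, an amine or a methyl ester at this position would fall relative to carboxy and acetamido.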